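The source may hold more compounds than are shown below. What is called first, only, known or untested is meant among the compounds shown, and "the series" means these compounds.

Measured in an assay on CHO cells for displacement of a labelled ligand from melatonin receptor type 1A (Homo sapiens), with a stated time of 120 min; on this read-out higher numbers stand for weaker inhibition and lower numbers for stronger inhibition:
- compound 1 `CCC(=O)NCC1CCc2c(OC)cccc2N1C`: 0.03 nM
- compound 2 `CCC(=O)NCC1CCc2ccccc2N1CC(=O)NC`: > 10000 nM
- compound 3 `CCNC(=S)NCC1CCc2ccccc2N1`: 305 nM.

For compound 2 the assay returns only a limit, > 10000 nM, so its true value is unknown beyond that bound; this is the limit of > 10000 nM in this assay, at which 1 of the 3 values shown sits, the weakest position among the three compounds shown. Within the data shown here, compound 1 sits at the strong end and compound 3 in between, and no single-point step connects any of these three, so each stands on its own.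

Compound 4 `CCC(=O)NCC1CCc2ccccc2N1Cc1ccccc1` has not yet been measured in this assay. It differs from compound 2 in one place: phenyl in place of methylcarbamoyl on a saturated chain carbon bound to a nitrogen on an aromatic ring in a ring. The group that enters is the benzyl type substituent on the ring nitrogen, while the amide-bearing chain of compound 2 leaves.

Since compound 2 gives only a limit, the step to compound 4 cannot be read as a number from the data; the direction is expected to be toward stronger inhibition, beyond the scatter. The expected change reads an at least 20-fold lower number from compound 2 to compound 4 (1.30 log units; beyond the scatter). Compound 4 is estimated at 500 nM, with a range from 50 nM to 5000 nM.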

Compound 4, inhibition constant: 37 nM
Compound 4: the middle estimate sits 14-fold (1.13 log units) above what was measured; the whole stated range lies above it.
By their numbers in this assay, from the lowest: compound 1; then compound 4; then compound 3. At a limit, above all of these: compound 2.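

Among these compounds, the first step at this position reads an at least 270-fold lower number from compound 2 to compound 4 (2.43 log units; beyond the scatter) in this assay. The reading for compound 2 is a limit of the assay, not a number: the limit of > 10000 nM in this assay, at which 1 of the 4 values shown sits. The step still shows that the group on a saturated chain carbon bound to a nitrogen on an aromatic ring in a ring can decide the outcome, with (methylcarbamoyl)methyl giving way to benzyl and compound 4 reaching 37 nM.

The single exchange removes methylcarbamoyl and brings in phenyl together, so the compounds shown do not separate the loss of one from the gain of the other. Going by these compounds, how a longer chain such as phenethyl, a carboxylic acid or an amine would read on this carbon also remains open.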